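The source may hold more compounds than are shown below. What is called first, only, known or untested is meant among the compounds shown, and "the series" means these compounds.

Compound 2, `Cc1ccc(Oc2c(/C=N\OCc3c(Cl)c(-c4ccc(F)cc4)nn3C)c(C)nn2C)cc1`, gives 80% in a functional assay on SMMC-7721 cells (Homo sapiens) for inhibition, read by MTT assay, with a stated time of 72 h, tested at 25 uM; a lower number here means less inhibition, a higher number more inhibition at the concentration tested (going by the name of the read-out). It is the only number shown; the two other values are limits. Compound 1, `CCc1nn(C)c(CO/N=C/c2c(C)nn(C)c2Oc2cccc(Cl)c2)c1Cl`, sits at a limit of < 80%. Compound 3, `CCc1nn(C)c(CO/N=C/c2c(C)nn(C)c2Oc2ccc(Br)cc2)c1Cl`, likewise sits at a limit of < 80%. Among the measured compounds shown here, the one measured step, a step that the two limits leave unreadable from compound 1 to compound 3, is therefore of unreadable size; the only evidence is the limit of < 80% in this assay, at which 2 of the 3 values shown sit. Compound 4, `Cc1nn(C)c(Oc2ccc(OC(F)(F)F)cc2)c1/C=N\OCc1c(Cl)c(-c2ccc(F)cc2)nn1C`, differs from compound 2 by trifluoromethoxy in place of methyl on an aromatic carbon. For the measured compounds named here, no measured step touches this change, so no shift beyond the scatter is expected, and compound 4 is estimated at 72%, between 50% and 88%. That estimate means an expected step of a number 8 percentage points lower from compound 2 to compound 4 (within the scatter), with a fair chance that only a limit is reported.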

Compound 4, a percentage reported as inhibition, at one concentration (the size of the read-out at that concentration, not a potency): 80%
Compound 4: middle estimate off by 8 percentage points, on the low side; the measured number falls inside the stated range.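

In this assay, trifluoromethoxy in place of methyl on the aromatic carbon para to a large group gives no change at the digits printed from compound 2 to compound 4 (within the scatter). Among the compounds shown here, this is the first readable step, and it shows that the larger group, which adds an oxygen and three fluorines, leaves the read-out unmoved at this position. The only other step cannot be read, as its two ends are limits: the limit of < 80% in this assay, at which 2 of the 4 values shown sit.

As far as these compounds go, whether an amine or a carboxylic acid at this position would also leave the read-out unmoved stays open. So does the effect of replacing the 4-fluorophenyl group shared by compound 2 and compound 4.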